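Fluoro to Hydrogen on an Aromatic Carbon: Two Cases

The source may hold more compounds than are shown below. What is called first, only, known or untested is meant among the compounds shown, and "the series" means these compounds.

Measured so far in a functional assay on Hs-578T cells (Homo sapiens) for inhibition, read by sulforhodamine B assay, with a stated time of 48 h; a lower number here means a stronger inhibitor of growth, a higher number a weaker inhibitor of growth:
compound 1 `COc1cc(OC)cc(-c2ccc(-c3ccc(C(=N)N)c(F)c3)s2)c1`: 1470 nM
compound 2 `N=C(N)c1ccc(-c2ccc(-c3ccc(Cl)cc3)s2)cc1F`: 726 nM
compound 3 `N=C(N)c1ccc(-c2ccc(-c3ccc(Cl)cc3)s2)cc1`: 200 nM

Of the three, compound 1 has the highest number, compound 2 the next, and compound 3 the lowest. The difference between the core of compound 1 and the core of compound 2 is not broken down here; the two values only show that compound 1 stands higher than compound 2 in this assay.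

Compound 2 and compound 3 differ in one place: hydrogen in place of fluoro on an aromatic carbon. That change gave a 3.6-fold lower number from compound 2 to compound 3 (0.56 log units; beyond the scatter).

Compound 4 `COc1cc(OC)cc(-c2ccc(-c3ccc(C(=N)N)cc3)s2)c1` is not yet measured. Within the data shown here, it differs from compound 1 by hydrogen in place of fluoro on an aromatic carbon, which is the same change, made at a place described in the same words, as the one from compound 2 to compound 3. Because the one measured case gave a 3.6-fold lower number from compound 2 to compound 3 (0.56 log units; beyond the scatter), a step of about the same size is expected here, namely a 3.6-fold lower number from compound 1 to compound 4 (0.55 log units; beyond the scatter). This rests on a single pair, so the expectation is uncertain. Compound 4 is therefore estimated to give 410 nM in this assay. The expected range for compound 4 runs from 180 nM to 950 nM.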

Compound 4, concentration for 50% growth inhibition: 1990 nM
Beside the measured number, compound 4's estimate is 4.9-fold (0.69 log units) below it; the measured number lies above the stated range.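

In this assay, hydrogen in place of fluoro on an aromatic carbon gave a 1.4-fold higher number from compound 1 to compound 4 (0.13 log units; within the scatter), so on the core of compound 1 this change has no effect that can be told from the scatter. The two pairs show that the size of this step was not constant across the two cores, and that a drop seen on one core cannot simply be assumed on the other. They do not show which difference between the cores accounts for this, or how the change would behave on any further core, and the contrast rests on one pair for each core: the same change on two cores in this assay, a 3.6-fold lower number (0.56 log units; beyond the scatter) from compound 2 to compound 3 and a 1.4-fold higher number (0.13 log units; within the scatter) from compound 1 to compound 4, 4.9-fold (0.69 log units) apart, beyond the scatter of two such steps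

The compounds shown leave open whether a different group in place of the fluoro, such as a methyl or a nitrile, would also track the core in this way. They also leave open how the same change would behave if an amine or a carboxylic acid stood on the aromatic ring at the far end of the molecule from the fluoro.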